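Rhodanine-type arylidene series: amino position swap on the benzylidene

The source may hold more compounds than are shown below. What is called first, only, known or untested is meant among the compounds shown, and "the series" means these compounds.

Measured so far in a functional assay on FM3A cells (Mus musculus) for cytotoxicity, read by cell counting, with a stated time of 2 days; on this read-out lower numbers stand for stronger inhibition and higher numbers for weaker inhibition:
- compound 1, `Nc1cccc(/C=C2\SC(=O)N(Cc3cccc(Cl)c3)C2=O)c1`: 164000 nM
- compound 2, `CC(C)(C)c1ccc(CN2C(=O)S/C(=C\c3cccc(N)c3)C2=O)cc1`: 188000 nM
- compound 3, `Nc1ccc(/C=C2\SC(=O)N(Cc3ccc(Cl)cc3)C2=O)cc1`: 60000 nM

Compound 3 has the lowest number of the three in this assay; the gap to compound 1 is the nearer one and the gap to compound 2 the wider one, and both lie beyond the usual scatter. Compounds 1 and 2 both carry a 3-aminophenyl group on the double-bonded chain carbon, while compound 3 carries a 4-aminophenyl group there; no two of the three differ in only one place, so no single change can be isolated from the measured set.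

Compound 4, `Nc1cccc(/C=C2\SC(=O)N(Cc3ccc(Cl)cc3)C2=O)c1`, keeps the benzyl substituent of compound 3 and differs from it only in the amino-bearing ring: 3-aminophenyl in place of 4-aminophenyl on a double-bonded chain carbon bound to a double-bonded ring carbon. Both compounds with a 3-aminophenyl group sit clearly above compound 3 in this assay, so a step upward, beyond the scatter, is expected on going from compound 3 to compound 4, though the benzyl substituent also changes between those pairs and the size is uncertain. The expected step of a 2.0-fold higher number from compound 3 to compound 4 (0.30 log units; within the scatter) reflects this. For compound 4 the estimate is 120000 nM, with a plausible range from 50000 nM to 300000 nM.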

Compound 4, half-maximal inhibitory concentration: 246000 nM
Compound 4: the middle estimate sits 2.1-fold (0.31 log units) below what was measured; low and high end bracket the measured number.
By their numbers in this assay, from the lowest: compound 3; then compounds 1, 2 and 4 (each within the scatter of the next).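

In this assay, for the compounds shown here, 3-aminophenyl in place of 4-aminophenyl on a double-bonded chain carbon bound to a double-bonded ring carbon gives a 4.1-fold higher number from compound 3 to compound 4 (0.61 log units; beyond the scatter), the first reading of this position with the rest of the molecule held constant. With 3-aminophenyl kept, the two changes on the benzyl substituent stay within the scatter: chloro in place of tert-butyl on an aromatic carbon gives a 1.3-fold higher number from compound 2 to compound 4 (0.12 log units; within the scatter), and 4-chlorophenyl in place of 3-chlorophenyl on a saturated chain carbon bound to an amide-type nitrogen in a ring gives a 1.5-fold higher number from compound 1 to compound 4 (0.18 log units; within the scatter), so among these four compounds the only step beyond the scatter is the one at the amino-bearing ring. Nothing at hand bears on the reason for that step.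

As far as these compounds go, the step at the amino-bearing ring rests on a single pair, so it remains open whether 4-aminophenyl would give the same gap alongside the 3-chlorobenzyl or 4-tert-butylbenzyl groups. Also open is how a hydroxyphenyl or dimethylaminophenyl group would read at this position, since only the two aminophenyl groups are shown there.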